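Diaryl urea series: trifluoromethyl to chloro, compound 3 to 4

The compounds below may be only part of what the source reports. "The series", "measured", "known", "first", "only" and "open" are said of these compounds alone.

Measured in a functional assay on CAKI-1 cells (Homo sapiens) for inhibition, read by sulforhodamine B assay, with a stated time of 48 h, tested at 10 uM; a higher number here means a weaker effect of the compound at the concentration tested, a lower number a stronger effect:
compound 1 `COc1cc2cc(Oc3ccc(NC(=O)Nc4ccc(C)cc4)cc3)c(C)nc2cc1OC`: 98.2%
compound 2 `COc1cc2cc(Oc3ccc(NC(=O)Nc4cccc(C(F)(F)F)c4)cc3)c(C)nc2cc1OC`: 9.13%
compound 3 `COc1cc2cc(Oc3ccc(NC(=O)Nc4ccc(Cl)c(C(F)(F)F)c4)cc3)c(C)nc2cc1OC`: -8.92%

Compound 3 stands lowest of the three numbers in this assay; compound 2 is nearest, compound 1 furthest, and both gaps are beyond the scatter. The steps leading to compound 3 are a number 107.1 percentage points lower from compound 1 to compound 3 (beyond the scatter) and a number 18.1 percentage points lower from compound 2 to compound 3 (beyond the scatter), while a number 89.1 percentage points lower from compound 1 to compound 2 (beyond the scatter) accounts for most of the drop from compound 1.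

Compound 4 `COc1cc2cc(Oc3ccc(NC(=O)Nc4ccc(Cl)c(Cl)c4)cc3)c(C)nc2cc1OC` differs from compound 3 by chloro in place of trifluoromethyl on an aromatic carbon. Among the compounds with values here, no measured step exchanges trifluoromethyl for chloro; the nearest information is that compound 2, which carries trifluoromethyl and hydrogen, and compound 3, which carries trifluoromethyl and chloro, both sit near the bottom of the scale, so the 3,4-disubstituted pattern of compound 4 keeps the chloro that compound 2 lacks. The expected step in this assay is therefore small, a number 8.9 percentage points higher from compound 3 to compound 4 (within the scatter), in the upward direction at most, and possibly none beyond the scatter. Compound 4 is expected to give about 0% in this assay, within -15% to 20%.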

Compound 4, a percentage reported as activity, at one concentration (the size of the read-out at that concentration, not a potency): 21.8%
Estimate against measurement, compound 4: 21.8 percentage points below; the measured number lies above the stated range.
By their numbers in this assay, from the lowest: compound 3; then compound 2; then compound 4; then compound 1.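

In this assay, within the data shown here, trifluoromethyl and chloro are not interchangeable on this aromatic carbon: chloro in place of trifluoromethyl, with the neighbouring chloro kept, gives a number 30.7 percentage points higher from compound 3 to compound 4 (beyond the scatter), the first direct reading of this exchange. The 3,4-dichlorophenyl group also leaves a weaker effect than the 3-(trifluoromethyl)phenyl group, with a number 12.7 percentage points higher from compound 2 to compound 4 (beyond the scatter), yet a much stronger effect than the 4-methylphenyl group, with a number 76.4 percentage points lower from compound 1 to compound 4 (beyond the scatter), so two chloro groups recover most but not all of what these trifluoromethyl compounds reach at the tested concentration. What lies behind the difference between trifluoromethyl and chloro at this carbon cannot be said from the data shown.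

The compounds shown leave open how a 3-chlorophenyl group would read, which would separate the contribution of this chloro from that of the second one, and whether a nitrile, a methoxy group or an amine on the same carbon would fall nearer the trifluoromethyl or the chloro result. All of these readings come from a single concentration, so they tell only of a stronger or weaker effect at that concentration.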